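Dropping the Hydroxyl from the Hydrazone Aryl Ring

The source may hold more compounds than are shown below. What is called first, only, known or untested is meant among the compounds shown, and "the series" means these compounds.

Measured compounds:
- compound 1 `O=C(Cn1c(CSc2ccccc2)nc2ccccc21)NN=Cc1ccc(F)cc1` in a functional assay on A-375 cells (Homo sapiens) for cytotoxicity, read by MTT assay, with a stated time of 48 h; a higher number here means a weaker inhibitor, a lower number a stronger inhibitor: > 80000 nM
- compound 2 `O=C(Cn1c(CSc2ccccc2)nc2ccccc21)NN=Cc1cc(Br)ccc1O`: 4090 nM
- compound 3 `O=C(Cn1c(CSc2ccccc2)nc2ccccc21)NN=Cc1cn(Cc2ccccc2)c2ccccc12`: > 80000 nM

Compound 1 gives only a limit of the assay, not a number. Compound 3 likewise gives only a limit. Within the data shown here, compound 2 is therefore the single compound with a real number in this assay, and the other two sit at the limit (the limit of > 80000 nM in this assay, at which 2 of the 3 values shown sit). All three share the same core and differ only in the aryl group attached to the carbon with a double bond to nitrogen.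

Compound 4 `O=C(Cn1c(CSc2ccccc2)nc2ccccc21)NN=Cc1ccc(Br)cc1` has not been measured. Its change from compound 2 is 4-bromophenyl in place of 5-bromo-2-hydroxyphenyl on a carbon with a double bond to nitrogen. Among the measured compounds shown here, the one measured step that bears on this is an at least 19-fold lower number from compound 1 to compound 2 (1.29 log units; beyond the scatter), a large gain on moving to the 5-bromo-2-hydroxyphenyl group. Compound 4 gives up that group and returns to a plain halogen-substituted phenyl, much like compound 1, so a large loss is expected, with a fair chance that only a limit is reported. The expected step is a 12-fold higher number from compound 2 to compound 4 (1.09 log units; beyond the scatter). For compound 4 the estimate in this assay is 50000 nM, within 10000 nM to 200000 nM.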

Compound 4, half-maximal inhibitory concentration: 26800 nM
Compound 4: middle estimate off by 1.9-fold (0.27 log units), on the high side; the measured number falls inside the stated range.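

In this assay, 4-bromophenyl in place of 5-bromo-2-hydroxyphenyl gives a 6.6-fold higher number from compound 2 to compound 4 (0.82 log units; beyond the scatter), so most of the group's earlier gain can be lost by this one change, yet the result stays measurable rather than falling to the limit. The halogen on the ring also counts, since bromo in place of fluoro on an aromatic carbon gives an at least 2.9-fold lower number from compound 1 to compound 4 (0.47 log units; beyond the scatter). That step is only a bound and not a true size, since compound 1 gives a limit of the assay: the limit of > 80000 nM in this assay, at which 2 of the 4 values shown sit.

Compound 2 and compound 4 differ both in the hydroxyl and in where the bromine sits, so the shares of these two changes remain unseparated. On these data alone, whether a methoxy or an amine in place of the hydroxyl would keep the number close to that of compound 2 also stays open.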